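The compounds below may be only part of what the source reports. "The series", "measured", "known", "first", "only" and "open" are said of these compounds alone.

Measured so far in a functional assay on MDA-MB-231 cells (Homo sapiens) for cytotoxicity, read by MTT assay, with a stated time of 48 h; on this read-out higher numbers stand for weaker inhibition and lower numbers for stronger inhibition:
compound 1, `O=C(/C=C/c1ccc2c(c1)B(O)OC2)c1ccc(Cl)cc1`: 7900 nM
compound 2, `O=C(/C=C/c1ccc2c(c1)B(O)OC2)c1ccc(Cl)c(Cl)c1`: 3400 nM
compound 3, `Cc1ccc(C(=O)/C=C/c2ccc3c(c2)B(O)OC3)cc1C`: 5300 nM

Compound 1 gives the highest of the three numbers in this assay. Its nearest neighbour is compound 3, whose number lies within the scatter of its own, so the two cannot be told apart. Compound 2 stands furthest away, and the one single-point step among these compounds, a 2.3-fold lower number from compound 1 to compound 2 (0.37 log units; beyond the scatter), is beyond the scatter.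

Compound 4, `Nc1cccc(C(=O)/C=C/c2ccc3c(c2)B(O)OC3)c1`, has not yet been measured. It differs from compound 1 in one place: 3-aminophenyl in place of 4-chlorophenyl on a carbonyl carbon. For the measured compounds named here, only the step of a 2.3-fold lower number from compound 1 to compound 2 (0.37 log units; beyond the scatter) is available for comparison, and it tells of a different kind of change, an added chloro rather than a swap of one group for another on the carbonyl carbon, so no measured step bears directly on the change to compound 4. With nothing pointing one way or the other, the expected outcome is a number close to that of compound 1, and the estimated step is a 1.1-fold higher number from compound 1 to compound 4 (0.06 log units; within the scatter). For compound 4 the estimate in this assay is 9000 nM, with a range from 3500 nM to 25000 nM.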

Compound 4, half-maximal inhibitory concentration: 3200 nM
The estimate for compound 4 lay 2.8-fold (0.45 log units) above the measured number; the whole stated range lies above it.
By their numbers in this assay, from the lowest: compounds 4, 2, 3 and 1 (each within the scatter of the next, the first and the last beyond it).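

In this assay, 3-aminophenyl in place of 4-chlorophenyl on the carbonyl carbon gives a 2.5-fold lower number from compound 1 to compound 4 (0.39 log units; beyond the scatter), so the group at this position can be exchanged as a whole without the number rising. The earlier readable step came from adding a chloro to a ring that already carried one, whereas this result shows that a lower number than that of compound 1 can be reached with no chlorine at all. The 3-aminophenyl group has hydrogen-bond donors and acceptors by count and the 4-chlorophenyl group has none, but no measurement here ties the lower number to that difference or to any other.

This single step changes both the kind of group on the ring and the place it occupies, so it cannot show which of the two matters, and 3-chlorophenyl or 4-aminophenyl at the same carbonyl carbon would be needed to pull them apart. It also leaves open whether the free amine itself is needed, which a 3-methoxyphenyl or 3-acetamidophenyl group at this position would help to test.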